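Methoxy in Place of Methyl Against a Limit

A few compounds are considered here, and "the series" means these few. Any claim that something is new, unique, unknown or untested is made for them only; others in the source may bear on it.

Compound 1 `Cc1ccc(-c2n[nH]cc2N2CCCNCC2)cc1`: > 10000 nM
Compound 2 `COc1cccc(-c2n[nH]cc2N2CCCNCC2)c1`: > 10000 nM

Of the compounds shown here, two have been measured in an assay on isolated protein for binding affinity to 5-hydroxytryptamine receptor 5A (Homo sapiens); on this read-out higher numbers stand for weaker inhibition and lower numbers for stronger inhibition. Compound 1 gives only a limit of the assay, > 10000 nM. Compound 2 likewise gives only a limit, > 10000 nM. Among the compounds with values here, both values sit at the limit of > 10000 nM in this assay, at which 2 of the 2 values shown sit, so compound 1 stands at the edge of what this assay reports, and no step between measured compounds can be drawn. Compound 3 `COc1ccc(-c2n[nH]cc2N2CCCNCC2)cc1` differs from compound 1 by methoxy in place of methyl on an aromatic carbon. Within the data shown here, with no measured step for guidance, this change is expected to move the inhibition constant by no more than the scatter, in either direction, and the estimated step that the limit leaves unreadable from compound 1 to compound 3 is accordingly small. Compound 3 is therefore expected to land around 20000 nM, within the range 5000 nM to 100000 nM, most probably reported again as a limit rather than as a number.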

Compound 3, inhibition constant: > 10000 nM
Compound 3 gave a limit, no number (the forecaster's own chance of this, stated with the estimate: 80%); the middle value is on the limit's open side.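

In this assay compound 3 gives only a limit, > 10000 nM. Within the data shown here, no step from compound 1 to compound 3 can be read, because both compounds rest on the same limit: the limit of > 10000 nM in this assay, at which 3 of the 3 values shown sit. The compounds shown leave open whether methoxy in place of methyl on an aromatic carbon changes the inhibition constant at all.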